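This account rests on a few compounds, and the source may have more. Where it says the series, first, only, none or still open, it means among the compounds named here.

In a functional assay on BGC-823 cells (Homo sapiens) for inhibition, read by MTT assay, with a stated time of 72 h (a lower number here means a stronger inhibitor, a higher number a weaker inhibitor), compound 1 `O=C1/C(=C\c2ccccc2)c2c(ncn2COCc2ccccc2)CCN1Cc1ccccc1` gives 20400 nM. Compound 3 `Cc1cccc(CN2CCc3ncn(COCc4ccccc4)c3/C(=C/c3ccccc3)C2=O)c1`, at 14600 nM, cannot be told apart from it, while compound 2 `O=C1/C(=C\c2ccccc2)c2c(ncn2COCc2ccccc2)CCN1Cc1ccc(F)cc1`, at 72900 nM, is the weakest of the three. Compound 4 `O=C1/C(=C\c2ccccc2)c2c(ncn2COCc2ccccc2)CCN1Cc1ccc(Cl)cc1` differs from compound 1 in one place: chloro in place of hydrogen on an aromatic carbon. Two measured steps change the same benzyl group. Fluoro gave a 3.6-fold higher number from compound 1 to compound 2 (0.55 log units; beyond the scatter), and methyl gave a 1.4-fold lower number from compound 1 to compound 3 (0.15 log units; within the scatter). The fluoro step is the closer guide, since compound 2 also carries a halogen, so a weaker result is more likely than a stronger one. The expected step is a 1.7-fold higher number from compound 1 to compound 4 (0.23 log units; within the scatter), a rise that may not clear the usual scatter. For compound 4, the estimated value is 35000 nM, with an expected range of 12000 nM to 85000 nM.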

Compound 4, half-maximal inhibitory concentration: 75700 nM
Estimate against measurement, compound 4: 2.2-fold (0.34 log units) below, within the range that was stated.
By their numbers in this assay, from the lowest: compounds 3 and 1 (each within the scatter of the next); then compounds 2 and 4 (each within the scatter of the next).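

With a 3.7-fold higher number from compound 1 to compound 4 (0.57 log units; beyond the scatter) for chloro, a second halogen on this benzyl group now weakens the compound, which fluoro alone could not show. Trading fluoro for chloro gives a 1.0-fold higher number from compound 2 to compound 4 (0.02 log units; within the scatter) and no difference that can be told apart, so the two halogens behave alike here. The methyl-bearing benzyl group stands clearly apart, with a 5.2-fold higher number from compound 3 to compound 4 (0.71 log units; beyond the scatter) on going to the chlorinated one.

Going by these compounds, whether a bromo, a methoxy or an amine at this place would match the halogens remains open. Nothing available explains why either halogen raises the number.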